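Two Chloro Groups on a Shared Core, Tested for Toxicity

A few compounds are considered here, and "the series" means these few. Any claim that something is new, unique, unknown or untested is made for them only; others in the source may bear on it.

Of the compounds shown here, three built on the same core have been tested in a functional assay on MCF7 cells (Homo sapiens) for cytotoxicity, read by sulforhodamine B assay, with a stated time of 48 h; a lower number here means that less compound is tolerated, a higher number that more compound is tolerated. Compound 2 has the structure `ClCc1ccccc1Cn1cnc2c(Cl)ncnc21`. In this assay compound 2 reaches only the limit of the assay, > 100000 nM, and no number. Compound 1, with the structure `ClCc1ccccc1Cn1cnc2c(Cl)nc(Cl)nc21`, differs from compound 2 by the change (chloro in place of hydrogen on an aromatic carbon). In this assay compound 1 also stops at the limit, > 100000 nM. The step that the two limits leave unreadable from compound 2 to compound 1 therefore cannot be read in size, because both values sit at the limit of > 100000 nM in this assay, at which 3 of the 3 values shown sit.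

Compound 3 has the structure `ClCc1cccc(Cn2cnc3c(Cl)ncnc32)c1`. How its core differs from the core of compound 2 is not broken down here. In this assay compound 3 again gives only the limit, > 100000 nM.

Compound 4, with the structure `ClCc1cccc(Cn2cnc3c(Cl)nc(Cl)nc32)c1`, has not yet been measured. It differs from compound 3 by the change (chloro in place of hydrogen on an aromatic carbon), the same change that leads from compound 2 to compound 1, at a place described in the same words.

The step from compound 3 to compound 4 is expected to be small or unreadable, a step that the limit leaves unreadable from compound 3 to compound 4, because compound 3 sits at the limit of > 100000 nM in this assay, at which 3 of the 3 values shown sit, and the earlier step that the two limits leave unreadable from compound 2 to compound 1 was likewise hidden by the limit. Compound 4 is therefore expected to give about 200000 nM in this assay, most likely reported only as a limit, with an expected range from 60000 nM to 800000 nM.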

Compound 4, concentration lethal to 50% of the cells: > 100000 nM
Compound 4: only a limit was reported; the forecaster's own chance of this, stated with the estimate: 85%; the middle value does not contradict the limit.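

In this assay compound 4 gives > 100000 nM, which is a limit and not a number. No size can be read for the step between compound 3 and compound 4, because both stop at the same limit: the limit of > 100000 nM in this assay, at which 4 of the 4 values shown sit.

The compounds shown leave open whether the added chloro changes cytotoxicity at all, and at what concentration any of the four would become lethal to the cells.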